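The source may hold more compounds than are shown below. What is called first, only, known or untested is meant among the compounds shown, and "the series" means these compounds.

Measured in a functional assay on the whole organism for antagonist activity, with Mus musculus as the target; a higher number here means that more compound is needed for the effect, a lower number that less compound is needed:
Compound 1, `COc1cc(N)c(Cl)cc1NC(=O)C1CCN(Cc2ccc(Cl)cc2)CC1`, gives 1.2 mg/kg.
Compound 2, `CCCCN1CCC(C(=O)Nc2cc(Cl)c(N)cc2OC)CC1`, reaches only the assay limit > 10 mg/kg.
Compound 3, `COc1cccc(CN2CCC(C(=O)Nc3cc(Cl)c(N)cc3OC)CC2)c1`, reaches only the assay limit > 4 mg/kg.

Within the data shown here, compound 1 holds the only actual number in this assay; the other two values are limits. Compound 4, `CCCN1CCC(C(=O)Nc2cc(Cl)c(N)cc2OC)CC1`, differs from compound 1 in one place: ethyl in place of 4-chlorophenyl on a saturated chain carbon bound to an amine nitrogen in a ring. Among the measured compounds shown here, two measured steps bear on this change, both moving away from 4-chlorophenyl at the same place: an at least 8.3-fold higher number from compound 1 to compound 2 (0.92 log units; beyond the scatter) and an at least 3.3-fold higher number from compound 1 to compound 3 (0.52 log units; beyond the scatter). For the measured compounds named here, both go upward and beyond the scatter, and the first replaces the aryl group with a plain chain, as compound 4 does. Compound 4 is therefore expected to need clearly more compound than compound 1, a step of an 8.3-fold higher number from compound 1 to compound 4 (0.92 log units; beyond the scatter). The estimate for compound 4 is 10 mg/kg, between 3 mg/kg and 30 mg/kg.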

Compound 4, dose for half-maximal effect: > 10 mg/kg
Compound 4: a limit, no number (the forecaster's own chance of this, stated with the estimate: 60%); the middle value sits exactly at the limit.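

In this assay, the change from 4-chlorobenzyl to propyl gives an at least 8.3-fold higher number from compound 1 to compound 4 (0.92 log units; beyond the scatter), so a second plain chain, shorter than that of compound 2, also falls short of compound 1. Compound 4 gives only a limit: the limit of > 10 mg/kg in this assay, at which 2 of the 4 values shown sit. The steps from compound 2 to compound 4 and from compound 3 to compound 4 cannot be read, as both ends of each are limits.

The compounds shown leave open how far compound 2, compound 3 and compound 4 lie beyond their limits. They also leave open whether an unsubstituted benzyl or a 4-fluorobenzyl group at this place would match 4-chlorobenzyl.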